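The compounds below may be only part of what the source reports. "The series", "measured", "known", "first", "only" and "open" are said of these compounds alone.

The measured compounds and their values:
compound 1, `Cc1ccsc1/C=C(/SCc1ccc(F)cc1)C(=O)c1ccc(Br)cc1`, 50000 nM
compound 2, `Cc1ccsc1/C=C(/SCc1ccc(Cl)cc1)C(=O)c1ccc(Br)cc1`, 25000 nM
compound 3, `COc1cc(/C=C(/Sc2ccc(Br)cc2)C(=O)c2ccc(Br)cc2)ccc1O`, 1000 nM

In a functional assay on DU-145 cells (Homo sapiens) for inhibition, read by trypan blue exclusion, with a stated time of 96 h (on this read-out higher numbers stand for weaker inhibition of growth and lower numbers for stronger inhibition of growth), compound 1 gives the highest of the three numbers. Compound 2 lies closest to it, a 2.0-fold lower number from compound 1 to compound 2 (0.30 log units; within the scatter), a step that falls within the scatter and so carries no clear message on its own. For the measured compounds named here, compound 3 lies furthest away, and its number sits beyond the scatter below that of compound 1; compound 3 differs from compound 1 in more than one place, however, so no single step connects them.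

Compound 4, `O=C(/C(=C\c1ccc(O)cc1)SCc1ccc(F)cc1)c1ccc(Br)cc1`, has not yet been measured. It differs from compound 1 in one place: 4-hydroxyphenyl in place of 3-methylthiophen-2-yl on a double-bonded chain carbon bound to a double-bonded chain carbon. Going by the values given here, no measured step covers this exact change. Among the compounds with values here, the only measured compound carrying a hydroxyphenyl group on the chain is compound 3, which sits far below compound 1, but it also differs elsewhere, so that comparison is only a rough guide. A step towards stronger inhibition of growth is therefore expected, a 10-fold lower number from compound 1 to compound 4 (1.00 log units; beyond the scatter), though its size is uncertain. Compound 4 is expected to give 5000 nM, with a range from 1000 nM to 25000 nM.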

Compound 4, concentration for 50% growth inhibition: 10000 nM
For compound 4 the middle estimate is 2.0-fold (0.30 log units) below the measured one; the range from low to high includes it.
By their numbers in this assay, from the lowest: compound 3; then compound 4; then compounds 2 and 1 (each within the scatter of the next).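

In this assay, the change on the double-bonded chain carbon gives a 5.0-fold lower number from compound 1 to compound 4 (0.70 log units; beyond the scatter). For the compounds shown here, this is the first single change to move the number beyond the scatter, as the only earlier single step, chloro in place of fluoro, stayed within it, so this position responds to what it carries, though only modestly in this one example. The change swaps a five-membered aromatic ring with 1 hetero atom and no hydrogen-bond donor for a six-membered aromatic ring of carbon only with 1 hydrogen-bond donor, and no available data say which of these differences, if any, accounts for the step.

The compounds shown leave open whether the hydroxy group or the change of ring carries the step, a question that a plain phenyl group at this place could help to answer. They also leave open how a 4-aminophenyl group would read here, and whether the same swap would give a step of similar size with chloro in place of fluoro, as in compound 2.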